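Urotensin receptor series: sulfonyl in place of pyrazinyl

A few compounds are considered here, and "the series" means these few. Any claim that something is new, unique, unknown or untested is made for them only; others in the source may bear on it.

Among the measured compounds shown here, compound 3 `CCN1CCN(c2cccc3c2CN([C@H](CCCNc2cncc(OC)n2)c2ccc(OC)c(OC)c2)C3=O)CC1` holds the lowest number of the three measured so far: in an assay on RMS13 cells for displacement of a labelled ligand from Urotensin-2 receptor (Homo sapiens), read by scintillation proximity assay (on this read-out lower numbers stand for stronger inhibition and higher numbers for weaker inhibition), compound 3 gives 8 nM. Compound 1 `CCN1CCN(c2cccc3c2CN([C@H](CCCNCc2cccs2)c2ccc(OC)c(OC)c2)C3=O)CC1` gives 18 nM and compound 2 `CCN1CCN(c2cccc3c2CN([C@H](CCCNC(=O)c2cccs2)c2ccc(OC)c(OC)c2)C3=O)CC1` gives 18 nM; the two steps to compound 3 read a 2.3-fold lower number from compound 1 to compound 3 (0.35 log units; beyond the scatter) and a 2.3-fold lower number from compound 2 to compound 3 (0.35 log units; beyond the scatter), while no change at the digits printed from compound 1 to compound 2 (within the scatter).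

Compound 4 `CCN1CCN(c2cccc3c2CN([C@H](CCCNS(=O)(=O)c2c[nH]cn2)c2ccc(OC)c(OC)c2)C3=O)CC1` differs from compound 3 in one place: (1H-imidazol-4-yl)sulfonyl in place of 6-methoxypyrazin-2-yl on an amine nitrogen.

The measured steps bear on this only indirectly. The swap from a methyl-linked to a carbonyl-linked thiophene gave no movement, and the two steps onto the 6-methoxypyrazin-2-yl group gave modest gains of equal size. For the measured compounds named here, no measured pair shows a sulfonyl, nor an imidazole, on this amine nitrogen, so the new group has no direct precedent. The working expectation is that the gain seen on going to compound 3 is given back, returning compound 4 to about the level of compound 1 and compound 2, so a modest rise in this assay is expected, a 2.5-fold higher number from compound 3 to compound 4 (0.40 log units; beyond the scatter).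

Compound 4 is therefore estimated at 20 nM in this assay, with a range from 8 nM to 50 nM.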

Compound 4, inhibition constant: 25 nM
Beside the measured number, compound 4's estimate is 1.3-fold (0.10 log units) below it, within the range that was stated.
By their numbers in this assay, from the lowest: compound 3; then compounds 1, 2 and 4 (each within the scatter of the next).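

In this assay the (1H-imidazol-4-yl)sulfonyl group, the only sulfonyl shown on this amine nitrogen, gives up the advantage held by 6-methoxypyrazin-2-yl, with a 3.1-fold higher number from compound 3 to compound 4 (0.49 log units; beyond the scatter) as the reading for this change. Set against the two thiophene groups, the same sulfonyl reads a 1.4-fold higher number from compound 1 to compound 4 (0.14 log units; within the scatter) and a 1.4-fold higher number from compound 2 to compound 4 (0.14 log units; within the scatter) as its two steps, so a sulfonyl-linked imidazole, a carbonyl-linked thiophene and a methyl-linked thiophene all stand level here, and among the four compounds only the directly attached 6-methoxypyrazin-2-yl of compound 3 stands apart from the rest. No measurement at hand offers an explanation for that separation.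

The sulfonyl and the imidazole enter together in this step, and separating them would take a pair such as a thiophene-2-sulfonyl group against the (thiophen-2-yl)carbonyl group, or an imidazole joined directly to the amine nitrogen against the 6-methoxypyrazin-2-yl group. Going by these compounds, how the read-out responds to a simple methyl or a carboxylic acid on this chain, or to a longer chain carrying the 6-methoxypyrazin-2-yl amine, also remains open.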